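The source may report more compounds than this note shows. Statements on the series, on what has been measured and on what is new or still open speak of the compounds shown alone.

Measured so far:
- compound 1 `CC1=C(C(=O)Nc2ccc(Br)cc2)C(c2ccc(Cl)cc2Cl)N=C(SCc2ccccc2)N1` — 22.1%
- compound 2 `CC1=C(C(=O)Nc2ccc(Br)cc2)C(c2ccc(Cl)cc2Cl)N=C(SCc2ccccc2Cl)N1` — 36.4%
- compound 3 `COc1ccc(C2N=C(SCc3ccccc3)NC(C)=C2C(=O)Nc2ccc(Br)cc2)cc1` — 16.4%

In a functional assay on the whole organism (artery, strain albino) with Rattus norvegicus as the target, with a stated time of 300 min, at a dose of 10 mg/kg by the oral route (a lower number here means less inhibition, a higher number more inhibition at the dose given (going by the name of the read-out)), compound 3 gives 16.4%. Its number is the smallest of the three, but the step of a number 5.7 percentage points lower from compound 1 to compound 3 (within the scatter) is within the scatter, so these two cannot be told apart; only compound 2 stands clearly apart from compound 3.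

Compound 4 `COc1ccc(C2N=C(SCc3ccccc3Cl)NC(C)=C2C(=O)Nc2ccc(Br)cc2)cc1` is the next compound to be measured. It differs from compound 3 in one place: chloro in place of hydrogen on an aromatic carbon. The same change has already been measured once, on the core carrying the 2,4-dichlorophenyl group, where going from compound 1 to compound 2 gave a number 14.3 percentage points higher from compound 1 to compound 2 (beyond the scatter), a modest rise that lies beyond the scatter. Among the measured compounds shown here, there is no other measured step of this kind, so the expectation rests on that single comparison.

A step of similar size and direction is therefore expected here, a number 13.6 percentage points higher from compound 3 to compound 4 (beyond the scatter). Compound 4 is expected to give about 30%, with a range from 20% to 42%.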

Compound 4, a percentage reported as inhibition, in the whole organism at one dose (the size of the read-out at that dose, not a potency): 17.9%
Estimate against measurement, compound 4: 12.1 percentage points above; the measured number lies below the stated range.
By their numbers in this assay, from the lowest: compounds 3, 4 and 1 (each within the scatter of the next); then compound 2.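

The chloro that turns benzylsulfanyl into (2-chlorobenzyl)sulfanyl gives a number 1.5 percentage points higher from compound 3 to compound 4 (within the scatter) in this assay, so on the core carrying 4-methoxyphenyl, this change brings no rise that can be told from the scatter. Replacing 2,4-dichlorophenyl with 4-methoxyphenyl while the chloro is present gives a number 18.5 percentage points lower from compound 2 to compound 4 (beyond the scatter), which shows that the higher number of compound 2 does not carry over to the other core. Even so, the four compounds only hint that the gain from the chloro depends on the core, since neither pair of steps can be separated: the same change on two cores in this assay, a number 14.3 percentage points higher (beyond the scatter) from compound 1 to compound 2 and a number 1.5 percentage points higher (within the scatter) from compound 3 to compound 4, 12.8 percentage points apart, within the scatter of two such steps; the same change on two cores in this assay, a number 5.7 percentage points lower (within the scatter) from compound 1 to compound 3 and a number 18.5 percentage points lower (beyond the scatter) from compound 2 to compound 4, 12.8 percentage points apart, within the scatter of two such steps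

A further core carrying the same pair of benzyl groups would be needed to test that hint. On these data alone, it also remains open how a fluoro or an amine would behave in place of this chloro on either core.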